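The source may hold more compounds than are shown below. What is called first, only, known or untested is meant among the compounds shown, and "the series" means these compounds.

Compound 1 `COC(=O)c1ccc(N2C(N)=NC(N)=NC2(C)C)cc1`: 4.26
Compound 2 `CC(C)(C)c1ccc(N2C(N)=NC(N)=NC2(C)C)cc1`: 6.4
Compound 3 `CC1(C)N=C(N)N=C(N)N1c1ccc(Br)cc1`: 6.24

In an assay for inhibition of Dihydrofolate reductase (Rattus norvegicus) (a higher number here means a more potent compound, by a factor of ten per unit of this negative logarithm, a lower number a less potent compound), compound 3 stands second highest of the three. Its nearest neighbour is compound 2, with a number 0.16 log units lower from compound 2 to compound 3 (within the scatter); its furthest is compound 1, with a number 1.98 log units higher from compound 1 to compound 3 (beyond the scatter). Compound 4 `CC1(C)N=C(N)N=C(N)N1c1ccc(C(F)(F)F)cc1` differs from compound 3 in one place: trifluoromethyl in place of bromo on an aromatic carbon. For the measured compounds named here, two measured steps touch this position. The step of a number 1.98 log units higher from compound 1 to compound 3 (beyond the scatter) was large, while a number 0.16 log units lower from compound 2 to compound 3 (within the scatter) stayed within the scatter, so two unlike groups at this place gave almost the same number. Going by the values given here, no measured step shows trifluoromethyl here. The expectation is therefore a step of a number 0.04 log units lower from compound 3 to compound 4 (within the scatter), not beyond the scatter. Compound 4 is estimated at 6.2, between 5.6 and 6.8.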

Compound 4, logarithm of the reciprocal of the active concentration, log(1/C): 6.06
Compound 4: the middle estimate sits 0.14 log units above what was measured; measured number inside the range.
By their numbers in this assay, from the lowest: compound 1; then compounds 4, 3 and 2 (each within the scatter of the next, the first and the last beyond it).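

In this assay the change from bromo to trifluoromethyl gives a number 0.18 log units lower from compound 3 to compound 4 (within the scatter) and so adds a third group that sits high at this place. Tert-butyl and trifluoromethyl do come apart, with a number 0.34 log units lower from compound 2 to compound 4 (beyond the scatter) as the first modest difference among these high groups, and with a number 1.80 log units higher from compound 1 to compound 4 (beyond the scatter) methoxycarbonyl stays alone at the low end. No evidence is available to explain these numbers. As far as these compounds go, how an amine, a carboxylic acid or a longer carbon chain would fare here stays open. So does whether an amide would share the low number of methoxycarbonyl.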